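Ethoxycarbonyl to hydroxymethyl on the shared core

The source may hold more compounds than are shown below. What is called first, only, known or untested is meant among the compounds shown, and "the series" means these compounds.

In a functional assay on Rec1 cells (Homo sapiens) for inhibition, read by luminescence and CellTiter-Glo, with a stated time of 72 h (a higher number here means a weaker inhibitor, a lower number a stronger inhibitor), compound 3 `C/C=C/C(=O)Nc1ccc(Cn2nc(-c3ccc(Oc4ccccc4)cc3)cc2C(=O)OCC)cc1` gives 13100 nM as its value, within the scatter of compound 1 `C/C=C/C(=O)Nc1ccc(Cn2nc(-c3ccc(Oc4ccccc4)cc3)cc2C(=O)O)cc1` at 23600 nM on the same read-out. Compound 2 `O=C(CCl)Nc1ccc(Cn2nc(-c3ccc(Oc4ccccc4)cc3)cc2CO)cc1` gives 400 nM and so stands well apart from compound 3 on the numbers.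

Compound 4 `C/C=C/C(=O)Nc1ccc(Cn2nc(-c3ccc(Oc4ccccc4)cc3)cc2CO)cc1` keeps the amide of compound 3 and carries hydroxymethyl in place of ethoxycarbonyl on an aromatic carbon.

Going by the values given here, the one measured step at this place, between the carboxylic acid and its ethyl ester, is small (a 1.8-fold lower number from compound 1 to compound 3 (0.26 log units; within the scatter)) and lies within the scatter. It says nothing direct about hydroxymethyl. Compound 2 does carry hydroxymethyl at this place, but with chloroacetyl rather than butenoyl on the amide, so its 400 nM cannot be credited to hydroxymethyl alone. Among the compounds with values here, no measured pair separates the two changes.

Part of the gap to compound 2 at 400 nM is therefore expected to carry over, giving a moderate drop in this assay with wide uncertainty. The expected size is an estimated 4.4-fold lower number from compound 3 to compound 4 (0.64 log units; beyond the scatter) in this series.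

For compound 4 the estimate is 3000 nM as the expected value, with a range from 600 nM to 14000 nM expected to hold most repeat measurements.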

Compound 4, half-maximal inhibitory concentration: 12200 nM
The estimate for compound 4 lay 4.1-fold (0.61 log units) below the measured number; the range from low to high includes it.
By their numbers in this assay, from the lowest: compound 2; then compounds 4, 3 and 1 (each within the scatter of the next).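

In this assay hydroxymethyl in place of ethoxycarbonyl on an aromatic carbon leaves the number within the scatter (a 1.1-fold lower number from compound 3 to compound 4 (0.03 log units; within the scatter)), and hydroxymethyl in place of carboxy at the same place does the same (a 1.9-fold lower number from compound 1 to compound 4 (0.29 log units; within the scatter)), so with prop-1-en-1-yl on the carbonyl carbon, the three groups tried here are not told apart by this read-out. Compound 2 and compound 4 share hydroxymethyl and differ in one place only, and prop-1-en-1-yl in place of chloromethyl on a carbonyl carbon gives a large step (a 31-fold higher number from compound 2 to compound 4 (1.48 log units; beyond the scatter)), which separates the two changes that compound 2 had left joined: among these compounds the low number travels with chloromethyl on the carbonyl carbon and not with hydroxymethyl. No measurement at hand accounts for either result.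

Still open, going by these compounds, is whether the flat response at the aromatic carbon extends to an aminomethyl group or a longer chain such as 2-hydroxyethyl. Also open, on these data alone, is whether ethenyl or bromomethyl on the carbonyl carbon would stay near compound 2 at 400 nM or near the prop-1-en-1-yl compounds, and whether chloromethyl keeps its number with ethoxycarbonyl or carboxy on the aromatic carbon.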